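Chloro to amino exchange on the shared core

The source may hold more compounds than are shown below. What is called first, only, known or untested is meant among the compounds shown, and "the series" means these compounds.

Measured compounds:
- compound 1 `ClCc1cccc(Cn2cnc3c(Cl)nc(Cl)nc32)c1`: 20400 nM
- compound 2 `ClCc1ccccc1Cn1cnc2nc(Cl)nc(Cl)c21`: 5750 nM

Of the compounds shown here, two have numbers so far. In a functional assay on OVCAR-5 cells (Homo sapiens) for cytotoxicity, read by sulforhodamine B assay, with a stated time of 48 h (on this read-out lower numbers stand for stronger inhibition of growth and higher numbers for weaker inhibition of growth), compound 1 gives 20400 nM, the highest of the two numbers. Its nearest neighbour is compound 2, which in this assay gives 5750 nM, a lower number that lies beyond the usual scatter; the two structures differ in more than one place, so only the two values themselves are to be read from that pair.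

The next compound, compound 3 `Nc1nc(Cl)c2ncn(Cc3cccc(CCl)c3)c2n1`, is derived from compound 1 by a single change: amino in place of chloro on an aromatic carbon. The change sits on the shared core, on an aromatic carbon between two ring nitrogen atoms, meta to a chloro group.

Among the compounds with values here, no step between measured compounds isolates this exchange, so the expected size rests on nothing measured. A modest step from compound 1 to compound 3 of a 1.1-fold higher number from compound 1 to compound 3 (0.03 log units; within the scatter) is expected, with the direction open and probably not beyond the scatter. For compound 3 the estimated value in this assay is 22000 nM, within a range of 7000 nM to 70000 nM.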

Compound 3, concentration for total growth inhibition: 25100 nM
Compound 3: the middle estimate sits 1.1-fold (0.06 log units) below what was measured; the range from low to high includes it.
By their numbers in this assay, from the lowest: compound 2; then compounds 1 and 3 (each within the scatter of the next).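

In this assay, amino in place of chloro on an aromatic carbon between two ring nitrogen atoms gives a 1.2-fold higher number from compound 1 to compound 3 (0.09 log units; within the scatter), so in this one pair the assay does not separate the two compounds. Within the data shown here, the earlier pair could not show this, as compound 1 and compound 2 differ in more than one place; this step is the first read on a single exchange, and here the chloro group at this carbon can give way to amino, with its 1 hydrogen-bond donor and 1 hydrogen-bond acceptor, without a change beyond the scatter. This is one pair on one core, so it sets no rule for the series, and no measurement at hand explains the result.

Still open, going by these compounds, is whether other groups on this carbon, such as a methylamino group, a hydroxyl or a methoxy group, would also leave the number within the scatter of compound 1. Also open, on these data alone, is whether the same exchange on the core of compound 2, or amino in place of the other chloro group on the shared core, would give a similarly small step.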